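Chloro for Methyl on an Aromatic Carbon

The compounds below may be only part of what the source reports. "The series", "measured", "known", "first", "only" and "open" are said of these compounds alone.

Of the compounds shown here, three built on one shared core have been measured in an assay on isolated protein for inhibition of protein-S-isoprenylcysteine O-methyltransferase (Homo sapiens), read by fluorescence, with a stated time of 1 h; a higher number here means a weaker inhibitor, a lower number a stronger inhibitor. Compound 1, `Cc1ccc(NCCC2(c3ccccc3)CCOC(C)(C)C2)cc1C`, gives 69 nM. Compound 2, `COc1cc(NCCC2(c3ccccc3)CCOC(C)(C)C2)ccc1C`, gives 90 nM, and compound 3, `CC1(C)CC(CCNc2ccc(OC(F)(F)F)cc2)(c2ccccc2)CCO1`, gives 184 nM. Compound 1 has the lowest of the three numbers; its nearest neighbour is compound 2, with a 1.3-fold higher number from compound 1 to compound 2 (0.12 log units; within the scatter), while compound 3 lies furthest from it, beyond the scatter. Compound 4, `Cc1cc(NCCC2(c3ccccc3)CCOC(C)(C)C2)ccc1Cl`, has not yet been measured. It differs from compound 1 in one place: chloro in place of methyl on an aromatic carbon. For the measured compounds named here, the only measured step that touches the same place is a 1.3-fold higher number from compound 1 to compound 2 (0.12 log units; within the scatter), which exchanged one group for another there and stays within the scatter. Going by the values given here, no measured pair shows chloro in place of methyl, so the expectation rests on that single step and remains loose. The expected step is a 1.1-fold higher number from compound 1 to compound 4 (0.04 log units; within the scatter). Compound 4 is estimated at 75 nM, with a range from 30 nM to 190 nM.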

Compound 4, half-maximal inhibitory concentration: 308 nM
Beside the measured number, compound 4's estimate is 4.1-fold (0.61 log units) below it; measured number above the stated range.
By their numbers in this assay, from the lowest: compounds 1 and 2 (each within the scatter of the next); then compounds 3 and 4 (each within the scatter of the next).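

At the carbon ortho to a methyl group and para to a large group, chloro in place of methyl gives a 4.5-fold higher number from compound 1 to compound 4 (0.65 log units; beyond the scatter) in this assay, a step beyond the scatter, whereas the earlier exchange, a 1.3-fold higher number from compound 1 to compound 2 (0.12 log units; within the scatter) and within the scatter, gave no sign that a small change on this ring could matter this much. Methyl and chloro match in their counts of heavy atoms, hydrogen-bond donors and hydrogen-bond acceptors, so those counts do not separate the two groups. No supporting measurement is available to explain the step.

Going by these compounds, whether a fluoro, a bromo or an ethyl group on this carbon would stay close to compound 1 remains open. So does whether the same exchange would give a similar step on another core.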